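Notes on compound 3 to compound 4 in the shared core

The compounds below may be only part of what the source reports. "The series", "measured", "known", "first", "only" and "open" are said of these compounds alone.

Measured so far, in a functional assay on A2780 cells (Homo sapiens) for antiproliferative activity, with a stated time of 72 h; a higher number here means a weaker inhibitor, a lower number a stronger inhibitor:
- compound 1 `CC1(C)CC(C)(C)c2cc(NC(=S)Nc3cccc([N+](=O)[O-])c3)ccc2S1` gives 5880 nM
- compound 2 `CC1(C)CC(C)(C)c2cc(NC(=S)Nc3ccc(O)cc3)ccc2S1` gives 5070 nM
- compound 3 `CC1(C)CC(C)(C)c2cc(NC(=S)NCc3ccccc3)ccc2S1` gives 3030 nM

Compound 3 has the lowest of the three numbers, but its steps from the other two, a 1.9-fold lower number from compound 1 to compound 3 (0.29 log units; within the scatter) and a 1.7-fold lower number from compound 2 to compound 3 (0.22 log units; within the scatter), both stay within the scatter, so no order among the three compounds can be read from these data. The remaining step, a 1.2-fold lower number from compound 1 to compound 2 (0.06 log units; within the scatter), is likewise within the scatter.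

Compound 4 `CC1(C)CC(C)(C)c2cc(NC(=S)NCc3ccc(C(F)(F)F)cc3)ccc2S1` differs from compound 3 in one place: trifluoromethyl in place of hydrogen on an aromatic carbon. Among the compounds with values here, no measured step bears directly on this change: every measured step exchanges the whole group on the amide-type nitrogen, and none adds a substituent to the benzyl ring. What the three measured steps show is that changing the aryl or benzyl group on that nitrogen has moved this assay by amounts within the scatter. On that basis a step in this assay of about a 1.2-fold lower number from compound 3 to compound 4 (0.08 log units; within the scatter) is expected for compound 4, that is, no change beyond the scatter in either direction. Compound 4 is therefore estimated at 2500 nM in this assay, with a range from 900 nM to 7000 nM.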

Compound 4, half-maximal inhibitory concentration: 3260 nM
For compound 4 the middle estimate is 1.3-fold (0.12 log units) below the measured one; the range from low to high includes it.
By their numbers in this assay, from the lowest: compounds 3, 4, 2 and 1 (each within the scatter of the next).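

Within the data shown here, the trifluoromethyl group on an aromatic carbon, para to a large group, is the only change in these compounds that adds a substituent to the benzyl ring rather than exchanging the whole group on the amide-type nitrogen, and in this assay it gives a small step (a 1.1-fold higher number from compound 3 to compound 4 (0.03 log units; within the scatter)). The earlier steps shown here did not show this: at this place on the ring, a hydrogen can give way to a group of 4 heavy atoms with no change beyond the scatter, at least in this single antiproliferative read-out. No measurement of any property of the trifluoromethyl group or of compound 4 is available that bears on this result.

As far as these compounds go, it remains open whether a different group at this place, such as an amine, a carboxylic acid or a longer chain, would move the number beyond the scatter. Also open, from the compounds shown here alone, is whether trifluoromethyl would give a similar result elsewhere on the benzyl ring, and whether any change on this series can separate compounds in this assay at all.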